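Swapping Methyl for Trifluoromethyl on an Amide Carbonyl

The source may report more compounds than this note shows. Statements on the series, on what has been measured and on what is new or still open speak of the compounds shown alone.

Of the compounds shown here, two have so far been measured in a functional assay on 3T3-L1 cells (Mus musculus) for inhibition, with a stated time of 20 min, tested at 20 uM; on this read-out lower numbers stand for less inhibition and higher numbers for more inhibition at the one concentration tested (going by the name of the read-out). Compound 1 `Cc1ccc(S(=O)(=O)N(Cc2ccccc2)Cc2cccc(F)c2F)cc1` gives -35.7%. Compound 2 `CC(=O)N(Cc1cn(Cc2cccc(F)c2F)nn1)Cc1cn(S(=O)(=O)c2ccc(C)cc2)c2ccccc12` gives 39.5%, the higher of the two numbers, and its gap to compound 1 lies beyond the usual scatter. Compound 3 `Cc1ccc(S(=O)(=O)n2cc(CN(Cc3cn(Cc4cccc(F)c4F)nn3)C(=O)C(F)(F)F)c3ccccc32)cc1` is not yet measured; it differs from compound 2 by trifluoromethyl in place of methyl on a carbonyl carbon. Among the measured compounds shown here, no measured pair shows this change, so its effect here is unknown. The expected step is a number 0.5 percentage points higher from compound 2 to compound 3 (within the scatter). For compound 3 the expected value in this assay is 40%, between 15% and 65%.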

Compound 3, a percentage reported as inhibition, at one concentration (the size of the read-out at that concentration, not a potency): 31.9%
Estimate against measurement, compound 3: 8.1 percentage points above; the measured number falls inside the stated range.
By their numbers in this assay, from the lowest: compound 1; then compounds 3 and 2 (each within the scatter of the next).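

In this assay trifluoromethyl in place of methyl on the carbonyl carbon gives a number 7.6 percentage points lower from compound 2 to compound 3 (within the scatter) and so leaves the two amides indistinguishable on this read-out. This first measured pair at the position shows that the carbonyl can carry either group with inhibition still within the scatter. No measurement shown offers an explanation for this result.

Going by these compounds, whether an amine or a longer chain on the carbonyl carbon would move the number beyond the scatter remains open. A reading at one concentration also leaves the potency of compound 2 and compound 3 unknown.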